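The source may hold more compounds than are shown below. What is called first, only, known or untested is meant among the compounds shown, and "the series" means these compounds.

Measured compounds:
- Compound 1, `CCCCCCCCCO[C@@H]1[C@@H](N)[C@@H](OCC(O)CNCCCO)O[C@H](CN)[C@H]1OCCCCCCCCC`: 13.7%
- Compound 2, `CCCCCCCCCO[C@@H]1[C@@H](N)[C@@H](OC[C@H](O)CN=[N+]=[N-])O[C@H](CN)[C@H]1OCCCCCCCCC`: 5.9%

Both compounds were tested in a toxicity assay on the whole organism (J774 cells) for cytotoxicity, with Mus musculus as the target, read by MTT assay, with a stated time of 24 h, tested at 30 uM; on this read-out higher numbers stand for a weaker effect at the one concentration tested and lower numbers for a stronger effect. On the numbers shown, compound 2 holds the smaller of the two values, but the only measured step, a number 7.8 percentage points lower from compound 1 to compound 2 (within the scatter), lies within the scatter, so compound 1 and compound 2 cannot be told apart on this read-out.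

Compound 3, `CCCCCCCCCO[C@@H]1[C@@H](N)[C@@H](OCC(O)CNCCN)O[C@H](CN)[C@H]1OCCCCCCCCC`, differs from compound 2 in one place: 2-((2-aminoethyl)amino)-1-hydroxyethyl in place of 2-azido-1-hydroxyethyl on a saturated chain carbon bound to an oxygen on a saturated carbon. The change once more replaces the 2-azido-1-hydroxyethyl group with a chain that carries amines, much as compound 1 carries a 1-hydroxy-2-((3-hydroxypropyl)amino)ethyl group at the same place; compound 1 gives 13.7% in this assay.

For the measured compounds named here, the one step that bears on this change, a number 7.8 percentage points lower from compound 1 to compound 2 (within the scatter), was within the scatter. The step from compound 2 to compound 3 is therefore expected to be small as well, and a number 4.1 percentage points higher from compound 2 to compound 3 (within the scatter) is the estimated size, with no direction that rises above the scatter. Compound 3 is expected to give 10% in this assay, with a range from 0% to 25%.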

Compound 3, a percentage reported as activity, at one concentration (the size of the read-out at that concentration, not a potency): 53%
Compound 3: middle estimate off by 43 percentage points, on the low side; measured number outside the range, above it.
By their numbers in this assay, from the lowest: compounds 2 and 1 (each within the scatter of the next); then compound 3.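

Unlike the earlier step, which stayed within the scatter, a number 47.1 percentage points higher from compound 2 to compound 3 (beyond the scatter) shows that in this assay the group on a saturated chain carbon bound to an oxygen on a saturated carbon can shift the read-out well beyond the scatter, here towards a weaker effect at the one concentration tested. The more telling result is a number 39.3 percentage points higher from compound 1 to compound 3 (beyond the scatter), which comes from only amino in place of hydroxymethyl on a saturated chain carbon, two bonds along the chain from an amine nitrogen; an amine nitrogen in this chain is therefore not enough on its own, since compound 1 has one and remains within the scatter of compound 2. Nothing available explains why this small exchange has such a large effect.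

The compounds shown leave open whether the weaker effect of compound 3 would survive if the amino group were replaced by a dimethylamino group or a carboxylic acid. They also leave open whether a longer chain, such as 3-aminopropyl in place of 2-aminoethyl, would shift the number further or bring it back towards that of compound 1.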